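The compounds below may be only part of what the source reports. "The series", "measured", "known", "first", "only" and "open" are said of these compounds alone.

Measured so far:
compound 1 `CCCc1ccc(B2OC(C)(C)C(C)(C)O2)cc1` — 25000 nM
compound 2 `CCCCCCCCCc1ccc(B2OC(C)(C)C(C)(C)O2)cc1` — 50000 nM

In an assay on isolated protein for inhibition of lipoprotein lipase (Homo sapiens), with a stated time of 1 h (a higher number here means a weaker inhibitor, a lower number a stronger inhibitor), compound 1 gives 25000 nM; this is the lowest of the two numbers, and its nearest neighbour is compound 2, with the step of a 2.0-fold higher number from compound 1 to compound 2 (0.30 log units; within the scatter). The shared core is kept in compound 3 `CC1(C)OB(c2ccc(-c3ccccc3)cc2)OC1(C)C`, which is not yet measured. The change from compound 1 is phenyl in place of propyl on an aromatic carbon. Among the measured compounds shown here, no measured step replaces a chain by a ring on this core; the only step at hand, from compound 1 to compound 2, lengthens the chain on the same aromatic carbon and stays within the scatter. On that basis no movement beyond the scatter is expected for compound 3 either, and the step from compound 1 to compound 3 is estimated at a 1.2-fold higher number from compound 1 to compound 3 (0.08 log units; within the scatter). Compound 3 is therefore expected to give about 30000 nM in this assay, in the range 10000 nM to 100000 nM.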

Compound 3, half-maximal inhibitory concentration: 4400 nM
Compound 3: middle estimate off by 6.8-fold (0.83 log units), on the high side; the whole stated range lies above it.
By their numbers in this assay, from the lowest: compound 3; then compounds 1 and 2 (each within the scatter of the next).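

In this assay, this aromatic carbon proves sensitive to the type of group it carries: phenyl in place of propyl gives a 5.7-fold lower number from compound 1 to compound 3 (0.75 log units; beyond the scatter), whereas hexyl in place of hydrogen on the chain gives a 2.0-fold higher number from compound 1 to compound 2 (0.30 log units; within the scatter). Among the three compounds, the only step beyond the scatter is the one that brings in a six-membered aromatic ring of carbon only, while added chain carbons alone do not move the number beyond the scatter; this reading rests on a single step of modest size. Nothing on hand bears on what lies behind this difference.

Going by these compounds, it remains open whether the aromatic ring itself is required, or whether a saturated ring such as cyclohexyl would give a similar number. On these data alone, the effect of an amine or a carboxylic acid on the same aromatic carbon also remains open.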